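Compound 4: a weak read-out expected

The source may hold more compounds than are shown below. What is called first, only, known or untested is meant among the compounds shown, and "the series" means these compounds.

Of the compounds shown here, three sharing one core have been measured in a functional assay on HOS cells (Homo sapiens) for antiproliferative activity, with a stated time of 72 h; a lower number here means a stronger inhibitor, a higher number a weaker inhibitor. Compound 1 `OC[C@H]1O[C@@H](n2cnc3c(NCc4cccc(F)c4)ncnc32)[C@H](O)[C@@H]1O` reads > 166000 nM, which is a limit. Compound 2 `OC[C@H]1O[C@@H](n2cnc3c(NCc4ccc(F)cc4)ncnc32)[C@H](O)[C@@H]1O` gives 13200 nM. Compound 3 `OC[C@H]1O[C@@H](n2cnc3c(NCc4ccc(Br)cc4)ncnc32)[C@H](O)[C@@H]1O` reads > 166000 nM, also a limit, so it has no numeric value. Compound 4 `OC[C@H]1O[C@@H](n2cnc3c(NCc4ccc(Cl)cc4Cl)ncnc32)[C@H](O)[C@@H]1O` differs from it as follows: 2,4-dichlorophenyl in place of 4-bromophenyl on a saturated chain carbon bound to a nitrogen on an aromatic ring. Among the compounds with values here, two measured steps bear on this change, both large: an at least 12-fold lower number from compound 1 to compound 2 (1.09 log units; beyond the scatter) and an at least 12-fold higher number from compound 2 to compound 3 (1.09 log units; beyond the scatter). Changes on this ring can therefore move the number far, but weighing most is the limit of > 166000 nM in this assay, at which 2 of the 3 values shown sit. A modest move to a lower number, or none, is expected. The estimated change is an at least 2.3-fold lower number from compound 3 to compound 4 (0.37 log units; beyond the scatter). For compound 4 the estimate is 70000 nM, with an expected range of 12000 nM to 166000 nM.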

Compound 4, half-maximal inhibitory concentration: > 166000 nM
Compound 4 ended at the assay's limit; the forecaster's own chance of this, stated with the estimate: 50%; middle value at least 2.3-fold (0.37 log units) from the limit.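

Replacing 4-fluorophenyl with 2,4-dichlorophenyl on the saturated chain carbon weakens the read-out in this assay, as an at least 12-fold higher number from compound 2 to compound 4 (1.09 log units; beyond the scatter) shows. The steps from compound 1 and from compound 3 to compound 4 cannot be read: both ends are limits. Compound 2 remains the only compound here with a numeric value, and the others stop at one point: the limit of > 166000 nM in this assay, at which 3 of the 4 values shown sit.

Open, as far as these compounds go, is whether any other aryl group at this place gives a numeric value in this assay. Plain phenyl or a pyridine ring would test whether halogens are needed here at all.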